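The compounds below may be only part of what the source reports. "The series", "measured", "known", "first", "only" and "open" are said of these compounds alone.

Measured in a functional assay on A549 cells (Homo sapiens) for cytotoxicity, read by MTT assay, with a stated time of 72 h; on this read-out lower numbers stand for an effect already at smaller amounts and higher numbers for an effect only at larger amounts of compound:
Compound 1 `O=c1cc(NC2CC2)cc(-c2ccccc2)o1`: > 30 uM
Compound 2 `COc1ccc(Nc2cc(C3CCCCC3)oc(=O)c2)cc1`: 4.62 uM
Compound 3 `COc1ccc(Nc2cc(-c3ccc4ccccc4c3)oc(=O)c2)cc1`: 0.15 uM

Compound 1 gives > 30 uM, which is a limit and not a number. Its standing is therefore known only as the limit of > 30 uM in this assay, at which 1 of the 3 values shown sits.

Compound 4 `O=c1cc(Nc2ccc(Br)cc2)cc(-c2ccccc2)o1` is not yet measured. It differs from compound 1 by 4-bromophenyl in place of cyclopropyl on a nitrogen on an aromatic ring, with 4-bromophenyl in place of cyclopropyl on a nitrogen on an aromatic ring.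

Compound 2 and compound 3 also carry a six-membered aromatic ring of carbon only on that nitrogen. Both give numbers in this assay, with compound 2 at 4.62 uM and compound 3 at 0.15 uM. For the measured compounds named here, they also differ from compound 4 elsewhere, so they offer only a rough guide, and no measured pair isolates this change. Even so, a clear move towards lower numbers seems likely, and the expected change is an at least 10-fold lower number from compound 1 to compound 4 (1.00 log units; beyond the scatter). Compound 4 is estimated at 3 uM, with an expected range of 0.5 uM to 15 uM.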

Compound 4, concentration for half-maximal effect: 0.31 uM
Estimate against measurement, compound 4: 9.7-fold (0.99 log units) above, and the stated range ends above it.
By their numbers in this assay, from the lowest: compound 3; then compound 4; then compound 2. At a limit, above all of these: compound 1.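

In this assay, for the compounds shown here, the pair compound 1 and compound 4 differs in one place only, so this is the first direct reading of what the group on this nitrogen does: 4-bromophenyl in place of cyclopropyl gives an at least 96-fold lower number from compound 1 to compound 4 (1.98 log units; beyond the scatter). The read-out on this core therefore depends strongly on which group sits at this position. Compound 1 gives > 30 uM, which is a limit and not a number, so the size of the step is a bound and not an exact figure: the limit of > 30 uM in this assay, at which 1 of the 4 values shown sits.

Whether the six-membered aromatic ring or the bromine on it accounts for the change stays open, and a plain phenyl on this nitrogen would separate the two. From the compounds shown here alone, it is also open how a carboxylic acid or an amine in place of the bromine would read in this assay.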